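A Smaller Acid Arm and Plasma Free Fraction

The compounds below may be only part of what the source reports. "The series", "measured", "known", "first", "only" and "open" are said of these compounds alone.

Compound 1 `CCc1c(CN(C)C(C)(C)C(=O)O)cccc1-c1nsc(-c2ccc(OC(C)C)c(C(F)(F)F)c2)n1` was tested in an ADME assay on a cell-free system (plasma, Homo sapiens) (on this read-out higher numbers stand for a larger free fraction and lower numbers for a smaller free fraction), where compound 1 gives 0.00004. This is the lowest of the three numbers seen so far. Compound 2 `CCc1c(CCCC(=O)O)cccc1-c1nsc(-c2cnc(OC(C)C)c(C(F)(F)F)c2)n1` gives 0.00031 in this assay, and compound 3 `CCc1c(-c2nsc(-c3ccc(CC(C)C)c(C#N)c3)n2)ccnc1CCCC(=O)O` gives 0.0019; both lie above compound 1 by gaps beyond the usual scatter. Compound 4 `CCc1c(CN(C)CC(=O)O)cccc1-c1nsc(-c2ccc(OC(C)C)c(C(F)(F)F)c2)n1` differs from compound 1 in one place: carboxymethyl in place of 1-carboxy-1-methylethyl on an amine nitrogen. Among the compounds with values here, no measured pair here shows what such a trim does to the free fraction, so the direction is uncertain. A modest rise is expected, and the expected step of a 2.0-fold higher number from compound 1 to compound 4 (0.30 log units; within the scatter) may well stay within the scatter. Compound 4 is estimated at 0.00008, in a range from 0.00003 to 0.00025.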

Compound 4, unbound fraction: 0.0049
Estimate against measurement, compound 4: 61-fold (1.79 log units) below, outside the stated range (above it).
By their numbers in this assay, from the lowest: compound 1; then compound 2; then compound 3; then compound 4.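

This position on an amine nitrogen proves highly sensitive in this assay: carboxymethyl in place of 1-carboxy-1-methylethyl gives a 120-fold higher number from compound 1 to compound 4 (2.09 log units; beyond the scatter) on an otherwise unchanged structure. The group goes from 6 heavy atoms to 4, while its hydrogen-bond donor and acceptor counts stay the same. Nothing available here explains the size of this jump. From the compounds shown here alone, whether a 1-carboxyethyl group on the same amine nitrogen would land nearer compound 1 or compound 4 remains open, as does the outcome for a longer chain, 2-carboxyethyl.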